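The source may report more compounds than this note shows. Statements on the series, on what has been measured and on what is new or still open speak of the compounds shown alone.

Compound 1 `COc1ccc(NC(=O)/C=C/C(=O)N2C/C(=C\c3ccc([N+](=O)[O-])cc3)C(=O)/C(=C/c3ccc([N+](=O)[O-])cc3)C2)cc1` gives 2900 nM in a functional assay on L1210 cells (Mus musculus) for cytotoxicity; a lower number here means a stronger inhibitor, a higher number a weaker inhibitor; the other two numbers in this set, compound 3 `O=C(/C=C/C(=O)N1C/C(=C\c2ccc([N+](=O)[O-])cc2)C(=O)/C(=C/c2ccc([N+](=O)[O-])cc2)C1)Nc1ccc(Cl)cc1` at 3600 nM and compound 2 `CC(=O)c1ccc(NC(=O)/C=C/C(=O)N2C/C(=C\c3ccccc3)C(=O)/C(=C/c3ccccc3)C2)cc1` at 5500 nM, both fall within the scatter of it, so the three compounds are not separated. For the measured compounds named here, the one single-point step, a 1.2-fold higher number from compound 1 to compound 3 (0.09 log units; within the scatter), likewise stays within the scatter. Compound 4 `Cc1cccc(C)c1NC(=O)/C=C/C(=O)N1C/C(=C\c2ccc([N+](=O)[O-])cc2)C(=O)/C(=C/c2ccc([N+](=O)[O-])cc2)C1` differs from compound 1 by 2,6-dimethylphenyl in place of 4-methoxyphenyl on an amide-type nitrogen. Going by the values given here, no measured step replaces the whole aryl group on the amide-type nitrogen, so the only guide is the narrow spread seen so far, and the expected step of a 1.2-fold higher number from compound 1 to compound 4 (0.08 log units; within the scatter) is therefore small, in no particular direction. Compound 4 is estimated at 3500 nM, with a range of 1500 nM to 8000 nM.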

Compound 4, half-maximal inhibitory concentration: 690 nM
Compound 4: middle estimate off by 5.1-fold (0.71 log units), on the high side, and the stated range ends above it.
By their numbers in this assay, from the lowest: compound 4; then compounds 1, 3 and 2 (each within the scatter of the next).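

In this assay the aryl group on the amide-type nitrogen can shift the number: 2,6-dimethylphenyl in place of 4-methoxyphenyl gives a 4.2-fold lower number from compound 1 to compound 4 (0.62 log units; beyond the scatter) and in place of 4-chlorophenyl gives a 5.2-fold lower number from compound 3 to compound 4 (0.72 log units; beyond the scatter) in the same direction. For the compounds shown here, the earlier methoxy-to-chloro change at this position stayed within the scatter, so this is the first change here that separates compounds. No available evidence accounts for this gain.

Still open, from the compounds shown here alone, is whether both methyl groups are needed for the step. A cyclohexyl group or an amine-bearing phenyl group here could also behave differently.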